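Swapping methylsulfanyl for methoxy on the shared core

The compounds below may be only part of what the source reports. "The series", "measured", "known", "first", "only" and "open" are said of these compounds alone.

Of the compounds shown here, three built on one core have been tested in a functional assay on the whole organism (strain Sprague-Dawley) for inhibition, with Rattus norvegicus as the target; on this read-out higher numbers stand for an effect only at larger amounts of compound and lower numbers for an effect already at smaller amounts. Compound 1 `CCc1cccc2c(=O)c(-c3nn[nH]n3)c[nH]c12` carries an ethyl group on an aromatic carbon, and for compound 1 the outcome is only a limit of the assay, > 25 mg/kg. Compound 2 `O=c1c(-c2nn[nH]n2)c[nH]c2c(F)cccc12` carries fluoro in the same place and gives 10 mg/kg. Compound 3 `CSc1cccc2c(=O)c(-c3nn[nH]n3)c[nH]c12` carries methylsulfanyl there and gives 25 mg/kg, the highest of the two numbers seen; its nearest neighbour is compound 2, with a 2.5-fold higher number from compound 2 to compound 3 (0.40 log units; beyond the scatter). The comparison with compound 1 shows a number no higher from compound 1 to compound 3 (the limit leaves the size open).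

Compound 4 `COc1cccc2c(=O)c(-c3nn[nH]n3)c[nH]c12` has not yet been measured. It differs from compound 3 in one place: methoxy in place of methylsulfanyl on an aromatic carbon. For the measured compounds named here, no measured step puts methoxy in or takes it out, so none speaks to this exchange directly. Going by the values given here, the two steps that touch methylsulfanyl, a number no higher from compound 1 to compound 3 (the limit leaves the size open) and a 2.5-fold higher number from compound 2 to compound 3 (0.40 log units; beyond the scatter), are the only guides, and they involve quite different groups. The present exchange keeps the substituent nearly unchanged in size, so compound 4 is expected, in this assay, to give a number close to that of its parent, with a 1.3-fold lower number from compound 3 to compound 4 (0.10 log units; within the scatter) not going beyond the scatter. The estimate for compound 4 is 20 mg/kg, between 8 mg/kg and 50 mg/kg.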

Compound 4, minimum effective dose: 0.312 mg/kg
Estimate against measurement, compound 4: 64-fold (1.81 log units) above; the whole stated range lies above it.
By their numbers in this assay, from the lowest: compound 4; then compound 2; then compound 3.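

Replacing methylsulfanyl with methoxy leaves the counts of heavy atoms and hydrogen-bond acceptors the same, yet in this assay it gives an 80-fold lower number from compound 3 to compound 4 (1.90 log units; beyond the scatter), which shows that groups matched on these counts can behave very differently at this position. Methoxy also stands well apart from fluoro, the group with the lowest earlier number, with a 32-fold lower number from compound 2 to compound 4 (1.51 log units; beyond the scatter), so this position can give a far lower number than the first three compounds revealed. The step from ethyl is an at least 80-fold lower number from compound 1 to compound 4 (1.90 log units; beyond the scatter), but compound 1 sits at a limit of the assay and not at a number, and the size of this step is only a floor: the limit of > 25 mg/kg in this assay, at which 1 of the 4 values shown sits.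

The compounds shown give no measured property that could explain why changing sulfur to oxygen in this substituent has so large an effect. They also leave open whether the low number belongs to methoxy alone or would carry over to a close relative on the same aromatic carbon, such as ethoxy, a hydroxyl group or an amine.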